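Compound 3 in the cytotoxicity series: what compound 2 suggests

The source may report more compounds than this note shows. Statements on the series, on what has been measured and on what is new or still open speak of the compounds shown alone.

Compound 2 `N#CC1=C(N)N(c2ccc(S(N)(=O)=O)cc2)C2=C(CCCC2)C1c1ccccc1Cl` holds the lowest of the two numbers: in a functional assay on Ehrlich cells (Mus musculus) for cytotoxicity, read by trypan blue exclusion, with a stated time of 2 h, tested at 50 ug/mL (on this read-out higher numbers stand for a stronger effect at the one concentration tested and lower numbers for a weaker effect), compound 2 gives 5%, while compound 1 `COc1ccc(C2C(C#N)=C(N)N(c3ccc(S(N)(=O)=O)cc3)C3=C2CCCC3)cc1` gives 100%, and the step of a number 95 percentage points lower from compound 1 to compound 2 (beyond the scatter) is large. Compound 3 `N#CC1=C(N)N(c2ccc(S(N)(=O)=O)cc2)C2=C(CCCC2)C1c1ccc(Cl)c(Cl)c1` differs from compound 2 by 3,4-dichlorophenyl in place of 2-chlorophenyl on a saturated ring carbon. Among the measured compounds shown here, no measured step concerns this change; the one known step involves a different change, so it gives no direction. Compound 3 is therefore expected at 25%, a step of a number 20 percentage points higher from compound 2 to compound 3 (beyond the scatter), within a wide range from 0% to 80%.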

Compound 3, a percentage reported as activity, at one concentration (the size of the read-out at that concentration, not a potency): 50%
Beside the measured number, compound 3's estimate is 25 percentage points below it; the range from low to high includes it.
By their numbers in this assay, from the lowest: compound 2; then compound 3; then compound 1.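

In this assay, the group on this saturated ring carbon now has three measured forms, and each change moves the read-out: a number 45 percentage points higher from compound 2 to compound 3 (beyond the scatter), and a number 50 percentage points lower from compound 1 to compound 3 (beyond the scatter). Compound 3 lies between the other two, so carrying chlorine on the phenyl ring does not by itself hold the number as low as in compound 2, yet 3,4-dichlorophenyl does not match 4-methoxyphenyl. No evidence is available on what lies behind these differences.

The compounds shown do not separate the effect of the added chlorine from that of the changed chlorine positions, which a 4-chlorophenyl group could do. As far as these compounds go, how a phenyl ring carrying an amine or a carboxylic acid would behave at this position also remains open.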